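Iodo to (tert-butoxycarbonyl)amino on the shared core

The compounds below may be only part of what the source reports. "The series", "measured", "known", "first", "only" and "open" are said of these compounds alone.

Compound 1 `CCNC(=O)CCc1cccc2c1B(O)OC2` gives > 100000 nM
Compound 2 `O=C(CCc1cccc2c1B(O)OC2)Nc1ccc(I)cc1` gives 50000 nM
Compound 3 `CC(C)(C)OC(=O)Nc1ccc(NC(=O)CCc2cccc3c2B(O)OC3)cc1` is not yet measured

Among the measured compounds shown here, in a functional assay on HCT-116 cells (Homo sapiens) for antiproliferative activity, read by MTT assay, with a stated time of 72 h (a lower number here means a stronger inhibitor, a higher number a weaker inhibitor), compound 2 stands at 50000 nM as the only actual number so far. The entry for compound 1 is a limit of the assay.

Compound 3 differs from compound 2 by (tert-butoxycarbonyl)amino in place of iodo on an aromatic carbon on an aromatic carbon, para to a large group. For the measured compounds named here, the one measured step is an at least 2.0-fold lower number from compound 1 to compound 2 (0.30 log units; that floor lies within the scatter) and it concerns a different change, on the amide-type nitrogen. Going by these compounds, its true size stays open because of the limit of > 100000 nM in this assay, at which 1 of the 2 values shown sits, and the series holds no measured replacement of iodo. In this assay no step beyond the scatter is therefore expected, in either direction. The expected step is no change at the digits printed from compound 2 to compound 3 (within the scatter) on present evidence. Compound 3 is expected at 50000 nM with an estimated range of 15000 nM to 100000 nM in this series.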

Compound 3, half-maximal inhibitory concentration: 24000 nM
Estimate against measurement, compound 3: 2.1-fold (0.32 log units) above; the measured number falls inside the stated range.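

In this assay, the replacement on the aromatic carbon para to a large group gives a 2.1-fold lower number from compound 2 to compound 3 (0.32 log units; beyond the scatter). Among the compounds shown here, this is the only measured replacement of iodo and its only step that is printed as beyond the scatter, whereas the earlier change on the amide-type nitrogen had a floor within it. The position therefore accepts (tert-butoxycarbonyl)amino, with 8 heavy atoms against 1 for iodo, with no loss of activity, although compound 3 still stands at 24000 nM.

Going by these compounds, the entry for compound 1 is a limit, and the size of the step from it to compound 2 stays open: the limit of > 100000 nM in this assay, at which 1 of the 3 values shown sits. How a free amine or a carboxylic acid at this aromatic carbon would compare with (tert-butoxycarbonyl)amino remains open, as does the effect of a longer chain on the amide-type nitrogen.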